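The compounds below may be only part of what the source reports. "The series", "measured", "known", "first", "only" and "open" are said of these compounds alone.

Measured so far in an ADME assay on microsomes from liver (Mus musculus, strain NMRI) for metabolic stability, tested at 2.5 uM; a lower number here means slower removal, a higher number faster removal of the compound:
- compound 1, `Brc1cccc2c1nnn2CC1CC1`, gives 7.7 mL/min/g
- compound 2, `FC(F)(F)c1cc(Br)c2nnn(CC3CC3)c2c1`, gives 7.7 mL/min/g
- compound 3, `Clc1cc(Br)c2nnn(CC3CC3)c2c1`, gives 11.4 mL/min/g

All three compounds share one core and differ only in the group on one aromatic carbon of the six-membered ring. Compound 3 stands apart from its two neighbours by a 1.5-fold higher number from compound 1 to compound 3 (0.17 log units; within the scatter) and by a 1.5-fold higher number from compound 2 to compound 3 (0.17 log units; within the scatter); both steps lie within the scatter, so the three numbers are, in effect, indistinguishable readings of the same behaviour.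

Compound 4, `Fc1cc(Br)c2nnn(CC3CC3)c2c1`, is the next member of this set. It differs from compound 3 in one place: fluoro in place of chloro on an aromatic carbon.

Among the measured compounds shown here, two measured steps bear on this change, since both swap the group at the same aromatic carbon: the step of a 1.5-fold higher number from compound 1 to compound 3 (0.17 log units; within the scatter) and the step of a 1.5-fold higher number from compound 2 to compound 3 (0.17 log units; within the scatter). Neither left the scatter, and the step of no change at the digits printed from compound 1 to compound 2 (within the scatter) between the other two groups at that position did not either. For the measured compounds named here, nothing measured so far involves fluoro, so the expectation rests only on the observation that three different groups at this position gave the same reading. The expected step in this assay is therefore none beyond the scatter, in no particular direction.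

Compound 4 is accordingly estimated at 9.5 mL/min/g, with a range from 5.5 mL/min/g to 16 mL/min/g, meaning an expected step of a 1.2-fold lower number from compound 3 to compound 4 (0.08 log units; within the scatter).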

Compound 4, intrinsic clearance in a liver preparation (reported as CLH), per the amount of preparation that the assay uses: 5.7 mL/min/g
The estimate for compound 4 lay 1.7-fold (0.22 log units) above the measured number, within the range that was stated.
By their numbers in this assay, from the lowest: compounds 4, 1, 2 and 3 (each within the scatter of the next).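

In this assay, fluoro gives the largest step yet seen at this aromatic carbon, a 2.0-fold lower number from compound 3 to compound 4 (0.30 log units; within the scatter), and it sits right at the edge of the usual scatter without leaving it. The other two new steps, a 1.4-fold lower number from compound 2 to compound 4 (0.13 log units; within the scatter) and a 1.4-fold lower number from compound 1 to compound 4 (0.13 log units; within the scatter), also stay within the scatter, so hydrogen, fluoro, chloro and trifluoromethyl now all give readings that cannot be told apart, and this holds for groups as different in size as a single fluorine atom and trifluoromethyl. No measurement is available that could explain the small spread among these four compounds.

Whether this position stays as indifferent with a quite different group, such as an amine, a carboxylic acid or a longer chain, remains open, since all four groups shown are small and only one of them, trifluoromethyl, holds more than one heavy atom. The bromo group is also the same in all four compounds, so what a nitrile or a methoxy group in its place would do to the removal rate in this assay is equally unknown.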